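Benzyl fluorination in a weak series of monoamine oxidase inhibitors

The compounds below may be only part of what the source reports. "The series", "measured", "known", "first", "only" and "open" are said of these compounds alone.

Measured compounds:
compound 1 `Cc1ccccc1CN1CCC(CCNC(=O)/C=C/c2cc(C(C)(C)C)c(O)c(C(C)(C)C)c2)CC1`: 69300 nM
compound 2 `CC(C)(C)c1cc(/C=C/C(=O)NCCC2CCN(Cc3ccc(F)cc3)CC2)cc(C(C)(C)C)c1O`: 59600 nM

Two compounds share a core and differ only in the aryl group on the saturated chain carbon bound to the ring amine nitrogen. In an assay on isolated protein for inhibition of Amine oxidase [flavin-containing] A (Homo sapiens), read by fluorescence, with stated times of 15 min and 20 min (on this read-out lower numbers stand for stronger inhibition and higher numbers for weaker inhibition), compound 1 gives 69300 nM, and compound 2 gives 59600 nM. The only step between them, a 1.2-fold lower number from compound 1 to compound 2 (0.07 log units; within the scatter), is within the scatter, so the two values cannot be ordered; compound 2 simply has the lower of the two numbers shown.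

Compound 3 `CC(C)(C)c1cc(/C=C/C(=O)NCCC2CCN(Cc3ccc(F)c(F)c3)CC2)cc(C(C)(C)C)c1O` has not been measured. It differs from compound 2 by fluoro in place of hydrogen on an aromatic carbon; cut one bond further out, the change reads 4-fluorophenyl to 3,4-difluorophenyl. Among the compounds with values here, no measured step tests a second fluoro on this ring; the nearest evidence is that swapping the whole aryl group, a 1.2-fold lower number from compound 1 to compound 2 (0.07 log units; within the scatter), left the number inside the scatter. The step of a 1.1-fold lower number from compound 2 to compound 3 (0.06 log units; within the scatter) is therefore expected to be small and without a clear direction. Compound 3 is estimated at 52000 nM in this assay, with a range from 20000 nM to 140000 nM.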

Compound 3, half-maximal inhibitory concentration: 64500 nM
Beside the measured number, compound 3's estimate is 1.2-fold (0.09 log units) below it, and the stated range covers the measured number.
By their numbers in this assay, from the lowest: compounds 2, 3 and 1 (each within the scatter of the next).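

In this assay, the 3,4-difluorophenyl group gives a direct reading of a fluoro on an aromatic carbon ortho to a fluoro group (a 1.1-fold higher number from compound 2 to compound 3 (0.03 log units; within the scatter)), and the second fluoro leaves the number inside the scatter. The comparison with the 2-methylphenyl group (a 1.1-fold lower number from compound 1 to compound 3 (0.03 log units; within the scatter)) also stays inside the scatter, so the three aryl groups on this saturated chain carbon cannot be ordered, and among compounds 1, 2 and 3 neither the swap of the whole aryl group nor the added fluoro separates the values. No supporting data bear on this result.

Still open, going by these compounds, is whether a larger or differently charged group on this aromatic ring, such as a methoxy, a nitrile or a carboxylic acid, would give a step beyond the scatter, or whether this ring simply has little bearing on the number. Equally open, on these data alone, is whether a longer chain between the ring amine nitrogen and the aryl group, or a change elsewhere in the shared core, would move the series away from these high values.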